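Adding a Methyl to the Chain of Compound 2

The compounds below may be only part of what the source reports. "The series", "measured", "known", "first", "only" and "open" are said of these compounds alone.

Measured compounds:
compound 1, `CC(CC(=O)O)N1Cc2ccc(NC(=O)CC3CCNCC3)cc2C1=O`, 2700 nM
compound 2, `O=C(O)CCN1Cc2ccc(NC(=O)c3ccc(C4CCNCC4)cc3)cc2C1=O`, 9600 nM
compound 3, `O=C(O)CCN1Cc2ccc(NC(=O)CCCC3CCNCC3)cc2C1=O`, 5900 nM

In a functional assay on a cell-free system (Platelet, plasma, Homo sapiens) for inhibition (on this read-out higher numbers stand for weaker inhibition and lower numbers for stronger inhibition), compound 2 gives the highest of the three numbers. Compound 3 sits nearest to it, within the scatter, while compound 1 lies beyond the scatter, with the lower number. Compound 4, `CC(CC(=O)O)N1Cc2ccc(NC(=O)c3ccc(C4CCNCC4)cc3)cc2C1=O`, keeps the rest of compound 2 unchanged and differs only in methyl in place of hydrogen on a saturated chain carbon bound to an amide-type nitrogen in a ring and a saturated chain carbon. Among the compounds with values here, no measured pair shows this change alone, so its effect is unknown here. The step of a 1.6-fold lower number from compound 2 to compound 4 (0.20 log units; within the scatter) is expected to be small, most likely a slight lowering of the number, but not clearly beyond the scatter. Compound 4 is therefore expected to give about 6000 nM in this assay, with a plausible range from 2000 nM to 18000 nM.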

Compound 4, half-maximal inhibitory concentration: 6200 nM
Compound 4: middle estimate off by 1.0-fold (0.01 log units), on the low side, within the range that was stated.
By their numbers in this assay, from the lowest: compound 1; then compounds 3, 4 and 2 (each within the scatter of the next).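

In this assay, methyl in place of hydrogen on the saturated chain carbon bound to an amide-type nitrogen in a ring, which turns 2-carboxyethyl into 1-(carboxymethyl)ethyl, gives a 1.5-fold lower number from compound 2 to compound 4 (0.19 log units; within the scatter) and so stays within the scatter. This pair is the only one shown that isolates the change, and it shows that this position accepts the added methyl without a clear shift in inhibition. No supporting measurement bears on this result.

The compounds shown leave open whether an ethyl group at this chain carbon would also stay within the scatter. They also leave open whether methyl here would give a similarly small step with a different amide side chain.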